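Moving one fluorine on compound 1

The compounds below may be only part of what the source reports. "The series", "measured", "known", "first", "only" and "open" are said of these compounds alone.

- Compound 1 `O=C(Nc1ccc(F)c(-c2nc3ncc(-c4ccc(F)cc4)cc3[nH]2)c1)N1CCCC1`: 0.095 h
- Compound 2 `O=C(Nc1ccc(F)c(-c2nc3ncc(-c4cccnc4F)cc3[nH]2)c1)N1CCCC1`: > 1.5 h (a limit)
- Compound 3 `Cc1nc(C)c(C(=O)Nc2ccc(F)c(-c3nc4ncc(-c5ccccc5Cl)cn4n3)c2)o1`: > 1.5 h (a limit)

For the measured compounds named here, in an ADME assay on microsomes from liver (Mus musculus) for metabolic stability, read by LC-MS (a higher number here means that the compound lasts longer, a lower number that the compound disappears faster), compound 1 gives 0.095 h, the only actual number among the three compounds. Going by the values given here, compound 2 and compound 3 each carry only a limit of this assay, and compound 3 also has a different core, so it offers no step here.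

Compound 4 `O=C(Nc1ccc(F)c(-c2nc3ncc(-c4ccccc4F)cc3[nH]2)c1)N1CCCC1` keeps the core of compound 1 and has one change: 2-fluorophenyl in place of 4-fluorophenyl on an aromatic carbon. Among the compounds with values here, the one measured step that bears on this is an at least 15-fold higher number from compound 1 to compound 2 (1.19 log units; beyond the scatter), large and beyond the scatter, with 2-fluoropyridin-3-yl in place of 4-fluorophenyl on an aromatic carbon. That step brought in a ring nitrogen, which compound 4 does not gain, as its entering group is a ring of carbon only. A much smaller rise is therefore expected in this assay, estimated as a 1.8-fold higher number from compound 1 to compound 4 (0.25 log units; within the scatter), and it may stay within the scatter. For compound 4 the expected value is 0.17 h, with an estimated range of 0.07 h to 0.5 h.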

Compound 4, half-life: 0.172 h
For compound 4 the middle estimate is 1.0-fold (0.01 log units) below the measured one; low and high end bracket the measured number.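

Moving the fluorine from 4-fluorophenyl to 2-fluorophenyl, with the ring still of carbon only, gives in this assay a 1.8-fold higher number from compound 1 to compound 4 (0.26 log units; within the scatter), so the place of the fluorine on this ring does not separate these two compounds. Holding the fluorine in the same ring place and exchanging only 2-fluoropyridin-3-yl for 2-fluorophenyl gives an at least 8.7-fold lower number from compound 2 to compound 4 (0.94 log units; beyond the scatter), which singles out the ring nitrogen as the one difference between that pair. Compound 2 carries a limit and not a number, so this step has a known lower bound but no known full size: the limit of > 1.5 h in this assay, at which 2 of the 4 values shown sit.

The compounds shown leave open whether a ring nitrogen gives the same result without the fluorine, as in an unsubstituted pyridin-3-yl. They also leave open how a methoxy group or an amine on this ring would read in this assay.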